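The source may hold more compounds than are shown below. What is called first, only, known or untested is meant among the compounds shown, and "the series" means these compounds.

Compound 1, `COc1ccc(-c2c(C(=O)c3cc(OC)c(OC)c(OC)c3)sc3ccccc23)cc1`, carries a 4-methoxyphenyl group on its core and in a functional assay on HeLa cells (Homo sapiens) for antiproliferative activity, read by MTT assay, with a stated time of 72 h (on this read-out higher numbers stand for weaker inhibition and lower numbers for stronger inhibition), compound 1 gives 4200 nM. Compound 2, `COc1ccc(-c2c(C(=O)c3cc(OC)c(OC)c(OC)c3)sc3ccccc23)cc1C`, differs from it by methyl in place of hydrogen on an aromatic carbon, and in this assay compound 2 gives 10000 nM, so that a 2.4-fold higher number from compound 1 to compound 2 (0.38 log units; beyond the scatter). Compound 3, `COc1cc(C(=O)c2sc3ccccc3c2Nc2ccc(C)cc2)cc(OC)c1OC`, differs from compound 1 by (4-methylphenyl)amino in place of 4-methoxyphenyl on an aromatic carbon; in this assay compound 3 gives 3500 nM, and a 1.2-fold lower number from compound 1 to compound 3 (0.08 log units; within the scatter), while a 2.9-fold lower number from compound 2 to compound 3 (0.46 log units; beyond the scatter).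

Compound 4, `COc1cc(C(=O)c2sc3cc(C)ccc3c2Nc2ccc(C)cc2)cc(OC)c1OC`, has not yet been measured. It differs from compound 3 by methyl in place of hydrogen on an aromatic carbon. Within the data shown here, this is the same kind of change as the one between compound 1 and compound 2, but not the same: there the methyl entered ortho to a methoxy group and meta to a large group on a six-membered ring of carbon only, whereas in compound 4 it enters a six-membered aromatic ring of carbon only that is part of a fused system of two rings, meta to a fused ring and para to a fused ring. Among the measured compounds shown here, the only measured instance of a methyl for hydrogen exchange, from compound 1 to compound 2, gave a modest weakening, so a change of similar direction but uncertain size is expected here, with the surrounding change from compound 1 to compound 3 having stayed within the scatter. For compound 4 the estimated step in this assay is a 1.6-fold higher number from compound 3 to compound 4 (0.20 log units; within the scatter). The value of compound 4 is therefore expected to be about 5500 nM, in an expected range from 2200 nM to 14000 nM.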

Compound 4, half-maximal inhibitory concentration: 980 nM
For compound 4 the middle estimate is 5.6-fold (0.75 log units) above the measured one; measured number below the stated range.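

In this assay, the methyl that enters on the six-membered aromatic ring of the fused system goes with a 3.6-fold lower number from compound 3 to compound 4 (0.55 log units; beyond the scatter), so a single added carbon is enough to move the number beyond the usual scatter on the core of compound 3. Set beside the earlier exchange, the same change does not carry over from one core to the other, neither in direction nor in size: the same change on two cores in this assay, a 2.4-fold higher number (0.38 log units; beyond the scatter) from compound 1 to compound 2 and a 3.6-fold lower number (0.55 log units; beyond the scatter) from compound 3 to compound 4, 8.5-fold (0.93 log units) apart, beyond the scatter of two such steps This shows that knowing only that methyl replaces hydrogen on an aromatic carbon does not tell what will happen in this series, but it does not show what sets the two steps apart, as the two pairs differ both in the core and in the ring that takes the methyl, and two pairs alone establish no rule.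

The compounds shown leave open whether the lower number of compound 4 is particular to methyl or would also appear with a chlorine atom, a methoxy group or an ethyl chain in the same place. They also leave open what the same methyl would do on the ring of the fused system in the core of compound 1, which carries 4-methoxyphenyl instead of (4-methylphenyl)amino.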